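The source may hold more compounds than are shown below. What is called first, only, known or untested is meant among the compounds shown, and "the series" means these compounds.

Compound 1 `CSc1nn(-c2ccccc2)c2nc(Nc3ccccc3)n(-c3ccccc3)c(=O)c12` is the parent of the set. In a functional assay on the whole organism (strain Wistar albino) for inhibition, with Rattus norvegicus as the target, read by paw edema, with a stated time of 3 h, at a dose of 25 mg/kg by the oral route (on this read-out higher numbers stand for more inhibition at the one dose given (going by the name of the read-out) and lower numbers for less inhibition), compound 1 gives 25.4%. Compound 2 `CSc1nn(-c2ccc(S(N)(=O)=O)cc2)c2nc(Nc3ccccc3)n(-c3ccccc3)c(=O)c12` carries the change (sulfamoyl in place of hydrogen on an aromatic carbon), and in this assay compound 2 gives 35.2%, a step of a number 9.8 percentage points higher from compound 1 to compound 2 (within the scatter). Compound 3 `O=c1c2c(Nc3ccc([N+](=O)[O-])cc3)nn(-c3ccccc3)c2nc(Nc2ccccc2)n1-c1ccccc1` differs from compound 1 by (4-nitrophenyl)amino in place of methylsulfanyl on an aromatic carbon; in this assay compound 3 gives 15.1%, a step of a number 10.3 percentage points lower from compound 1 to compound 3 (beyond the scatter), leaving compound 3 as the lowest of the three.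

Compound 4 `NS(=O)(=O)c1ccc(-n2nc(Nc3ccc([N+](=O)[O-])cc3)c3c(=O)n(-c4ccccc4)c(Nc4ccccc4)nc32)cc1` is not yet measured. It differs from compound 3 by sulfamoyl in place of hydrogen on an aromatic carbon, the same change that separates compound 2 from compound 1, placed on the core of compound 3 rather than that of compound 1. Because compound 1 to compound 2 moved by a number 9.8 percentage points higher from compound 1 to compound 2 (within the scatter), a step of similar size is expected, namely a number 8.9 percentage points higher from compound 3 to compound 4 (within the scatter). Compound 4 is therefore estimated at 24% in this assay, expected to fall between 14% and 34%.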

Compound 4, a percentage reported as inhibition, in the whole organism at one dose (the size of the read-out at that dose, not a potency): 39.1%
Beside the measured number, compound 4's estimate is 15.1 percentage points below it; the measured number lies above the stated range.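

Placed on the core of compound 3, sulfamoyl in place of hydrogen gives a step of a number 24 percentage points higher from compound 3 to compound 4 (beyond the scatter), and in this assay this step does not match the one seen on the parent: the same change on two cores in this assay, a number 9.8 percentage points higher (within the scatter) from compound 1 to compound 2 and a number 24 percentage points higher (beyond the scatter) from compound 3 to compound 4, 14.2 percentage points apart, beyond the scatter of two such steps. Read the other way, (4-nitrophenyl)amino in place of methylsulfanyl gives a step of a number 3.9 percentage points higher from compound 2 to compound 4 (within the scatter), so the drop seen on the parent is not repeated with sulfamoyl present: the same change on two cores in this assay, a number 10.3 percentage points lower (beyond the scatter) from compound 1 to compound 3 and a number 3.9 percentage points higher (within the scatter) from compound 2 to compound 4, 14.2 percentage points apart, beyond the scatter of two such steps. The two changes thus do not add up independently across these four compounds, but one pair of cores cannot show why, or whether this holds on any other core.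

The compounds shown leave open whether a carboxylic acid or methylsulfonyl in place of sulfamoyl would behave in the same way. They also leave open what an amine or a longer chain would do in place of (4-nitrophenyl)amino.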